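This account rests on a few compounds, and the source may have more. Where it says the series, first, only, none or still open, it means among the compounds named here.

In a functional assay on LNCaP cells (Homo sapiens) for antiproliferative activity, read by propidium iodide staining, with a stated time of 96 h (on this read-out lower numbers stand for stronger inhibition and higher numbers for weaker inhibition), compound 1 `CC(O)(CS(=O)(=O)c1cccc(OC(F)(F)F)c1)C(=O)Nc1ccc(S(F)(F)(F)(F)F)cc1` gives 21700 nM. Compound 2 `CC(O)(CS(=O)(=O)c1ccccc1OC(F)(F)F)C(=O)Nc1ccc(S(F)(F)(F)(F)F)cc1` shares its core and differs from it by one change, (2-(trifluoromethoxy)phenyl in place of 3-(trifluoromethoxy)phenyl on a sulfonyl sulfur), and in this assay compound 2 gives 12700 nM, which amounts to a 1.7-fold lower number from compound 1 to compound 2 (0.23 log units; within the scatter). Compound 3 `CC(O)(CS(=O)(=O)c1cccc(OC(F)(F)F)c1)C(=O)Nc1cccc(S(F)(F)(F)(F)F)c1` has a different core; how the cores of compound 1 and compound 3 differ is not broken down here. In this assay compound 3 gives 15100 nM, which sits within the scatter of both compound 2 and compound 1, so no order among the three measured compounds can be read from these numbers.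

Compound 4 `CC(O)(CS(=O)(=O)c1ccccc1OC(F)(F)F)C(=O)Nc1cccc(S(F)(F)(F)(F)F)c1` has not yet been measured. It stands to compound 3 as compound 2 stands to compound 1: the change is 2-(trifluoromethoxy)phenyl in place of 3-(trifluoromethoxy)phenyl on a sulfonyl sulfur, and the place lines of the two changes agree word for word, so it is the same change made on the core of compound 3. Its size is expected to resemble the earlier step because that step, a 1.7-fold lower number from compound 1 to compound 2 (0.23 log units; within the scatter), stayed within the scatter. The account expects a 1.6-fold lower number from compound 3 to compound 4 (0.20 log units; within the scatter) in this assay. Compound 4 is estimated at 9500 nM in this assay, with a range from 4500 nM to 20000 nM.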

Compound 4, half-maximal inhibitory concentration: 9000 nM
For compound 4 the middle estimate is 1.1-fold (0.02 log units) above the measured one, and the stated range covers the measured number.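

In this assay, putting 2-(trifluoromethoxy)phenyl in place of 3-(trifluoromethoxy)phenyl on a sulfonyl sulfur gives a 1.7-fold lower number from compound 3 to compound 4 (0.22 log units; within the scatter). Set beside the earlier step, the change reads the same on the two cores, with no difference that can be told apart: the same change on two cores in this assay, a 1.7-fold lower number (0.23 log units; within the scatter) from compound 1 to compound 2 and a 1.7-fold lower number (0.22 log units; within the scatter) from compound 3 to compound 4, 1.0-fold (0.01 log units) apart, within the scatter of two such steps. Yet each step on its own stays within the scatter, which means the agreement is one between two small steps; it does not show that the change itself moves the number, and two cores give no rule for any other core.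

The compounds shown leave open how the sulfonyl sulfur would read with a plain phenyl, or with a phenyl carrying a nitrile or a carboxylic acid in place of the trifluoromethoxy group. They also leave open whether the same change would give a similar step on a core with an amine in place of the hydroxyl group.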